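Aryl-pyrazole coumarin diesters: cytotoxicity on cervical cancer cells

The source may report more compounds than this note shows. Statements on the series, on what has been measured and on what is new or still open speak of the compounds shown alone.

Measured compounds:
compound 1, `CCOC(=O)c1c(-c2cc3ccccc3oc2=O)nn(-c2cccc(F)c2)c1C(=O)OCC`, 68000 nM;
compound 2, `COC(=O)c1c(-c2cc3ccccc3oc2=O)nn(-c2cccc(F)c2)c1C(=O)OC`, 76000 nM;
compound 3, `CCOC(=O)c1c(-c2cc3ccccc3oc2=O)nn(-c2ccc(Br)cc2)c1C(=O)OCC`, 250000 nM.

The three measured compounds were tested in a functional assay on HeLa cells (Homo sapiens) for cytotoxicity, read by MTT assay, with a stated time of 48 h; a lower number here means a stronger inhibitor, a higher number a weaker inhibitor. Compound 1 gives 68000 nM and compound 2 gives 76000 nM; the two lie within the scatter of each other, so no order between them is claimed. How the core of compound 2 differs from that of compound 1 is not broken down here. Compound 3 carries the change 4-bromophenyl in place of 3-fluorophenyl on an aromatic nitrogen relative to compound 1, and that change made the step of a 3.7-fold higher number from compound 1 to compound 3 (0.57 log units; beyond the scatter).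

The unmeasured compound 4, `COC(=O)c1c(-c2cc3ccccc3oc2=O)nn(-c2ccc(Br)cc2)c1C(=O)OC`, stands to compound 2 as compound 3 stands to compound 1: its change is 4-bromophenyl in place of 3-fluorophenyl on an aromatic nitrogen. The two place lines differ in the neighbouring group, ethoxycarbonyl in one case and methoxycarbonyl in the other, so this is the same kind of change rather than the same change. Because the earlier step of a 3.7-fold higher number from compound 1 to compound 3 (0.57 log units; beyond the scatter) was modest but beyond the scatter, a step of similar size is expected from compound 2, namely a 3.4-fold higher number from compound 2 to compound 4 (0.53 log units; beyond the scatter) in this assay. Compound 4 is therefore estimated at 260000 nM, with a range from 120000 nM to 550000 nM.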

Compound 4, half-maximal inhibitory concentration: 120000 nM
Compound 4: the middle estimate sits 2.2-fold (0.34 log units) above what was measured, and the stated range covers the measured number.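

Putting 4-bromophenyl in place of 3-fluorophenyl on an aromatic nitrogen gave a 1.6-fold higher number from compound 2 to compound 4 (0.20 log units; within the scatter) in this assay, so on this core the change alone cannot be said to have moved the number. Set beside the same change on the core of compound 1, the two steps cannot be told apart: the same change on two cores in this assay, a 3.7-fold higher number (0.57 log units; beyond the scatter) from compound 1 to compound 3 and a 1.6-fold higher number (0.20 log units; within the scatter) from compound 2 to compound 4, 2.3-fold (0.37 log units) apart, within the scatter of two such steps. This shows that nothing in these data separates the methoxycarbonyl core from the ethoxycarbonyl core in how the change carries over, but it does not show that the step is truly the same on both, as the evidence is a single pair of steps, one beyond the scatter and one within it.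

The compounds shown leave open how other groups on the aromatic nitrogen would behave, such as an unsubstituted phenyl, 4-fluorophenyl or 3-bromophenyl. They also leave open what a carboxylic acid, an amide or a longer chain in place of the ester groups would do in this assay.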